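Compound 3: a Methyl Added on the Ring of Compound 2

The source may hold more compounds than are shown below. What is called first, only, known or untested is meant among the compounds shown, and "the series" means these compounds.

Compound 2 `COc1cc2c(Oc3ccc(NC(=O)c4cc(-c5cccc(Cl)c5)nc5ccccc45)cc3F)ccnc2cc1OCCCN1CCCCC1` gives 11 nM in a functional assay on NCI-H460 cells (Homo sapiens) for cytotoxicity, read by MTT assay, with a stated time of 72 h; on this read-out higher numbers stand for weaker inhibition and lower numbers for stronger inhibition.
Compound 1 `COc1cccc(-c2cc(C(=O)Nc3ccc(Oc4ccnc5cc(OCCCN6CCCCC6)c(OC)cc45)c(F)c3)c3ccccc3n2)c1` gives 210 nM in this assay.

Compound 2 stands at the lower of the two numbers, separated from compound 1 by a 19-fold lower number from compound 1 to compound 2 (1.28 log units; beyond the scatter). Compound 3 `COc1cc2c(Oc3ccc(NC(=O)c4cc(-c5cccc(Cl)c5)nc5ccccc45)cc3F)ccnc2cc1OCCCN1CCC(C)CC1` differs from compound 2 by methyl in place of hydrogen on a saturated ring carbon, piperidin-1-yl becoming 4-methylpiperidin-1-yl. Among the compounds with values here, no measured step touches this ring; the only step known, a 19-fold lower number from compound 1 to compound 2 (1.28 log units; beyond the scatter), concerns a different part of the molecule and gives no guide. Compound 3 is therefore expected to show a 1.1-fold higher number from compound 2 to compound 3 (0.04 log units; within the scatter) in this assay, nothing beyond the scatter. The estimate for compound 3 is 12 nM, between 5 nM and 30 nM.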

Compound 3, half-maximal inhibitory concentration: 65 nM
Compound 3: the middle estimate sits 5.4-fold (0.73 log units) below what was measured; the whole stated range lies below it.
By their numbers in this assay, from the lowest: compound 2; then compound 3; then compound 1.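

Within the data shown here, the piperidin-1-yl group, which no earlier step touched, proves sensitive to change in this assay. A single added methyl, three ring bonds from the ring nitrogen, gives a 5.9-fold higher number from compound 2 to compound 3 (0.77 log units; beyond the scatter), so even this small change on the saturated ring carbon moves the number beyond the scatter. Nothing available accounts for this step.

As far as these compounds go, what a hydroxyl, an amine or a longer chain on this same ring carbon would do remains open. Also open, from the compounds shown here alone, is whether the methyl would have a similar effect in compound 1.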